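Compound 2 to compound 4: replacing 2-(hydroxymethyl)phenyl

The source may hold more compounds than are shown below. What is called first, only, known or untested is meant among the compounds shown, and "the series" means these compounds.

Measured so far in a physicochemical assay for solubility, in phosphate buffer, at pH 6.5; a higher number here means a more soluble compound, a lower number a less soluble compound:
- Compound 1 `CC(C)(C)c1ccccc1Oc1ncccc1NC(=O)Nc1ccc(C2(CO)CC2)cc1`: 5 ug/mL
- Compound 2 `CC(C)(C)c1ccccc1Oc1ncccc1NC(=O)Nc1ccc(-c2ccccc2CO)cc1F`: 2 ug/mL
- Compound 3 `CC(C)(C)c1ccccc1Oc1ncccc1NC(=O)Nc1ccc(N2CCCCC2)cc1`: 9 ug/mL

Compound 2 gives 2 ug/mL, the lowest of the three numbers, and its gaps to compound 1 and to compound 3 both lie beyond the scatter. The next compound, compound 4 `CC(C)N1CCC(COc2ccc(NC(=O)Nc3cccnc3Oc3ccccc3C(C)(C)C)c(F)c2)CC1`, has (1-isopropylpiperidin-4-yl)methoxy in place of 2-(hydroxymethyl)phenyl, on an aromatic carbon meta to a fluoro group and para to a large group: (1-isopropylpiperidin-4-yl)methoxy in place of 2-(hydroxymethyl)phenyl on an aromatic carbon.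

Among the measured compounds shown here, no measured step makes this exchange. For the measured compounds named here, the only step available is a 1.8-fold higher number from compound 1 to compound 3 (0.26 log units; within the scatter), which stays within the scatter and involves different groups, so it bears on the change only indirectly. Neither compound 1 nor compound 3 carries the 2-(hydroxymethyl)phenyl group, and both stand above compound 2. Going by the values given here, compound 3, with its piperidin-1-yl group, reaches 9 ug/mL, the highest number so far. On that slender basis, a rise beyond the scatter is expected in this assay, and its size is highly uncertain: a 13-fold higher number from compound 2 to compound 4 (1.10 log units; beyond the scatter). For compound 4 the estimated value is 25 ug/mL, with an expected range of 6 ug/mL to 120 ug/mL.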

Compound 4, solubility: 232 ug/mL
Beside the measured number, compound 4's estimate is 9.3-fold (0.97 log units) below it; measured number above the stated range.
By their numbers in this assay, from the lowest: compound 2; then compounds 1 and 3 (each within the scatter of the next); then compound 4.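

In this assay, among the compounds shown here, the exchange of 2-(hydroxymethyl)phenyl for (1-isopropylpiperidin-4-yl)methoxy on this aromatic carbon gives a 120-fold higher number from compound 2 to compound 4 (2.06 log units; beyond the scatter) and so opens a far wider gap than any seen among the earlier compounds. The only earlier step was a 1.8-fold higher number from compound 1 to compound 3 (0.26 log units; within the scatter) and it stayed within the scatter, so this is the one exchange shown at such a carbon that moves the number by a large step, and it does so with the fluoro group kept in place. For the compounds shown here, the single exchange takes away a six-membered aromatic ring of carbon only and a hydrogen-bond donor and brings in a six-membered non-aromatic ring with 1 hetero atom, and nothing measured here ties the step to any one of these parts.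

The compounds shown leave open whether the step belongs to the ring nitrogen with its isopropyl group, to the methoxy link, or to the loss of the 2-(hydroxymethyl)phenyl group itself. They also leave open whether a morpholin-4-yl ring or a dimethylamino group on the same link would give a similar number, and whether the exchange holds without the fluoro group.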